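Phenoxy in Place of Ethoxycarbonyl: Expecting Compound 4

The source may report more compounds than this note shows. Statements on the series, on what has been measured and on what is new or still open speak of the compounds shown alone.

Three compounds have been measured in a functional assay on BXPC-3 cells (Homo sapiens) for cytotoxicity, read by MTT assay, with a stated time of 72 h; on this read-out lower numbers stand for stronger inhibition and higher numbers for weaker inhibition:
Compound 1 `O=C1C(Nc2ccc(CO)cc2)=CC(=O)c2ncncc21`: 5700 nM
Compound 2 `CCc1ccc(-c2ccc(NC3=CC(=O)c4ncncc4C3=O)cc2)cc1`: 3100 nM
Compound 3 `CCOC(=O)c1ccc(NC2=CC(=O)c3ncncc3C2=O)cc1`: 5900 nM

Compound 3 stands at the highest of the three numbers, yet its distances to the others are small: a 1.0-fold higher number from compound 1 to compound 3 (0.01 log units; within the scatter) and a 1.9-fold higher number from compound 2 to compound 3 (0.28 log units; within the scatter), both within the scatter. Compound 4 `O=C1C(Nc2ccc(Oc3ccccc3)cc2)=CC(=O)c2ncncc21` differs from compound 3 by phenoxy in place of ethoxycarbonyl on an aromatic carbon. The step that bears on this most is a 1.8-fold lower number from compound 1 to compound 2 (0.26 log units; within the scatter), where an aromatic ring also entered in place of a small group; it too stayed within the scatter. Compound 4 is therefore expected to show a step of a 1.3-fold lower number from compound 3 to compound 4 (0.12 log units; within the scatter), lying within the scatter. The estimate for compound 4 in this assay is 4500 nM, with a range from 2000 nM to 10000 nM.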

Compound 4, half-maximal inhibitory concentration: 3600 nM
Estimate against measurement, compound 4: 1.3-fold (0.10 log units) above; low and high end bracket the measured number.
By their numbers in this assay, from the lowest: compounds 2, 4, 1 and 3 (each within the scatter of the next).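

In this assay, phenoxy brings a six-membered aromatic ring of carbon only onto this aromatic carbon, yet the change from ethoxycarbonyl stays within the scatter (a 1.6-fold lower number from compound 3 to compound 4 (0.21 log units; within the scatter)). The same holds for phenoxy against hydroxymethyl (a 1.6-fold lower number from compound 1 to compound 4 (0.20 log units; within the scatter)) and against 4-ethylphenyl (a 1.2-fold higher number from compound 2 to compound 4 (0.06 log units; within the scatter)), so all four groups at this place read alike within the scatter. Nothing available accounts for this sameness. From the compounds shown here alone, whether an amine or a carboxylic acid on this aromatic carbon would give a step beyond the scatter remains open.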